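The source may report more compounds than this note shows. Statements on the series, on what has been measured and on what is new or still open speak of the compounds shown alone.

Compound 1 `Cc1ncccc1-c1cnc(NCc2c(F)ccc3c2CCO3)c2nn(CC#N)c(=O)n12`: 4000 nM
Compound 2 `CN(c1ncco1)c1cnc(NCc2c(F)ccc3c2CCO3)n2cnnc12`: 67000 nM
Compound 3 `Cc1nccn1-c1cnc(NCc2c(F)ccc3c2CCO3)c2cn[nH]c(=O)c12`: 7000 nM

These three compounds have been measured in a physicochemical assay for solubility, read by LC-MS, in phosphate buffer, with a stated time of 24 h, at pH 7.4; on this read-out lower numbers stand for lower solubility and higher numbers for higher solubility. Compound 2 stands highest of the three numbers. Its nearest neighbour on that scale is compound 3 with 7000 nM, a gap beyond the usual scatter, and compound 1 with 4000 nM lies furthest from it, also beyond the scatter. Within the data shown here, no two of the three compounds differ in a single place, so no step between measured compounds can be drawn.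

Compound 4 `O=C1CCCN1c1cnc(NCc2c(F)ccc3c2CCO3)n2cnnc12` has not yet been measured in this assay. It differs from compound 2 in one place: 2-oxopyrrolidin-1-yl in place of methyl(1,3-oxazol-2-yl)amino on an aromatic carbon. The change sits on an aromatic carbon of a six-membered aromatic ring with 2 nitrogen, part of a fused or bridged system of two rings, two atoms from the ring nitrogen and para to a large group. The shared core and the remainder of compound 2 are kept.

Among the measured compounds shown here, nothing among the measured compounds shows how such an exchange moves the number in this assay. The writer therefore expects compound 4 to stay near compound 2. The expected step is a 1.2-fold higher number from compound 2 to compound 4 (0.08 log units; within the scatter), which is none beyond the scatter. Compound 4 is estimated at 80000 nM, with a range from 25000 nM to 250000 nM.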

Compound 4, solubility: 640000 nM
Compound 4: middle estimate off by 8.0-fold (0.90 log units), on the low side; measured number outside the range, above it.
By their numbers in this assay, from the lowest: compounds 1 and 3 (each within the scatter of the next); then compound 2; then compound 4.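

In this assay, the exchange of methyl(1,3-oxazol-2-yl)amino for 2-oxopyrrolidin-1-yl on this aromatic carbon gives the only single-place comparison among the compounds shown, and it produces a 9.6-fold higher number from compound 2 to compound 4 (0.98 log units; beyond the scatter). The group at this place, two atoms from the ring nitrogen and para to a large group, therefore matters to this read-out even with the shared core and the remainder of compound 2 kept. The exchange replaces a five-membered aromatic ring with 2 hetero atoms and 3 hydrogen-bond acceptors by a five-membered non-aromatic ring with 1 hetero atom, 1 double bond outside aromatic rings and 1 hydrogen-bond acceptor, but no measurement shown says which of these differences accounts for the step.

On these data alone, with a single pair, it remains open whether an open-chain amide such as acetamido, a morpholine ring or a carboxylic acid at this place would move the number in the same direction or by a similar amount. As far as these compounds go, it also remains open whether the same exchange would give a comparable step on the different cores of compound 1 and compound 3.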